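Acetylation of the free hydroxyl in two protected sugar series

This account rests on a few compounds, and the source may have more. Where it says the series, first, only, none or still open, it means among the compounds named here.

Of the compounds shown here, three have been measured in a functional assay on HeLa cells (Homo sapiens) for antiproliferative activity, read by sulforhodamine B assay; on this read-out higher numbers stand for weaker inhibition of growth and lower numbers for stronger inhibition of growth. Compound 1 `CCC[C@@H]1O[C@H](COCc2ccc3ccccc3c2)[C@@H](OCc2ccc3ccccc3c2)[C@H](OCc2ccc3ccccc3c2)[C@H]1O` carries three naphthylmethyl ethers, a propyl chain on the ring and a free hydroxyl. In this assay compound 1 gives only a limit, > 50000 nM. Compound 2 `CCC[C@@H]1O[C@H](COCc2ccc3ccccc3c2)[C@@H](OCc2ccc3ccccc3c2)[C@H](OCc2ccc3ccccc3c2)[C@H]1OC(C)=O` differs from compound 1 by acetyl in place of hydrogen on an oxygen on a saturated carbon. In this assay compound 2 likewise gives only a limit, > 50000 nM. The step that the two limits leave unreadable from compound 1 to compound 2 cannot be sized, because the limit of > 50000 nM in this assay, at which 2 of the 3 values shown sit, holds both ends of it.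

Compound 3 `CC(C)C[C@H]1O[C@H](COCc2ccccc2)[C@@H](OCc2ccccc2)[C@H](OCc2ccccc2)[C@H]1O` has a different core: three benzyl ethers and an isobutyl chain on the ring. How the core of compound 3 differs from that of compound 1 is not broken down here. In this assay, going by the values given here, compound 3 gives 43900 nM, the one value of the series that is a number rather than a limit.

Compound 4 `CC(=O)O[C@@H]1[C@@H](OCc2ccccc2)[C@H](OCc2ccccc2)[C@@H](COCc2ccccc2)O[C@@H]1CC(C)C` is the unmeasured member. It differs from compound 3 by acetyl in place of hydrogen on an oxygen on a saturated carbon, the same change that leads from compound 1 to compound 2, at the same kind of place. Among the compounds with values here, the only precedent for this change, from compound 1 to compound 2, is unreadable, and the starting point, compound 3, already sits close to the assay limit. For compound 4 the expected step is therefore a 1.0-fold higher number from compound 3 to compound 4 (0.01 log units; within the scatter), essentially flat. Compound 4 is estimated at 45000 nM in this assay, within 18000 nM to 120000 nM, with a fair chance that only a limit is reported.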

Compound 4, concentration for 50% growth inhibition: > 50000 nM
Compound 4: no number, only a limit; the forecaster's own chance of this, stated with the estimate: 55%; middle value at least 1.1-fold (0.04 log units) away from the limit.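

In this assay compound 4 gives only a limit, > 50000 nM. From the compounds shown here alone, the change from hydroxy to acetoxy on this core is an at least 1.1-fold higher number from compound 3 to compound 4 (0.05 log units; that floor lies within the scatter), so no stronger inhibition of growth appears with the acetyl group, but the printed floor does not establish a real loss of activity and the true size of the step remains unknown. The step on the core of compound 1 cannot be read, so there are no two sizes to compare and transfer of the effect from one core to the other is not shown; the only common feature is that both acetylated compounds end at the same limit: the limit of > 50000 nM in this assay, at which 3 of the 4 values shown sit.

Open, going by these compounds, is whether any group other than acetyl on this oxygen, such as a simple amine-bearing acyl group or a carboxylic acid-bearing acyl group, would give a readable number on either core. Going by these compounds alone, also open is how a longer chain in place of the isobutyl chain would read in this assay, starting from compound 3 at 43900 nM, the only measured number.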